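Solubility of a Hydroxyphenyl Analogue Estimated From a Limit

A few compounds are considered here, and "the series" means these few. Any claim that something is new, unique, unknown or untested is made for them only; others in the source may bear on it.

Of the compounds shown here, three sharing one core have been measured in a physicochemical assay for solubility, read by HPLC, using the shake flask method, measured as kinetic solubility, with a stated time of 2 h, at pH 7.4; a lower number here means a less soluble compound, a higher number a more soluble compound. Compound 1 `Cc1cc(NCc2cnccn2)n2nc(C)c(-c3ccccc3)c2n1` gives 7100 nM in this assay. Compound 2 `Cc1cc(Nc2ccccn2)n2nc(C)c(-c3ccccc3)c2n1` reaches only a limit of the assay, < 5000 nM, and not a number. Compound 3 `Cc1cc(NCc2ccccn2)n2ncc(-c3ccccc3C)c2n1` likewise reaches only a limit, < 5000 nM, so its standing is known just as a bound; the line the limit of < 5000 nM in this assay, at which 2 of the 3 values shown sit, records this shared limit. Among the compounds with values here, the one measured step, an at least 1.4-fold lower number from compound 1 to compound 2 (0.15 log units; that floor lies within the scatter), changes a group on a nitrogen, not the ring that differs between compound 3 and compound 4 `Cc1cc(NCc2ccccn2)n2ncc(-c3ccc(O)cc3)c2n1`, where the change is 4-hydroxyphenyl in place of 2-methylphenyl on an aromatic carbon. Within the data shown here, no measured step therefore bears on this change, and the expectation for compound 4 rests on the limit of compound 3 alone. Compound 4 is estimated at 8000 nM in this assay, within a range from 2500 nM to 25000 nM. This corresponds to an expected step of an at least 1.6-fold higher number from compound 3 to compound 4 (0.20 log units; that floor lies within the scatter), with a real chance that only a limit is again reported.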

Compound 4, solubility: 10900 nM
Beside the measured number, compound 4's estimate is 1.4-fold (0.13 log units) below it; the range from low to high includes it.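

In this assay, swapping 2-methylphenyl for 4-hydroxyphenyl on this aromatic carbon of the five-membered aromatic ring gives an at least 2.1-fold higher number from compound 3 to compound 4 (0.33 log units; beyond the scatter), which is beyond the scatter. Within the data shown here, the one earlier step changed only a group on a nitrogen, so this is the first reading of any change at this carbon, and it shows that the position can move the solubility number. Compound 3 gives only a limit of the assay, < 5000 nM, so the step is a floor and its full size stays unknown: the limit of < 5000 nM in this assay, at which 2 of the 4 values shown sit.

The methyl group leaves and the hydroxyl group enters in one step, and the compounds shown do not separate the two. On these data alone, whether a 4-aminophenyl or a 4-carboxyphenyl group on this carbon would give a similar number also remains open.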